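The source may hold more compounds than are shown below. What is called first, only, known or untested is meant among the compounds shown, and "the series" means these compounds.

Of the compounds shown here, three built on one shared core have been tested in an ADME assay on Vero cells (Chlorocebus sabaeus) for cytotoxicity, read by MTT assay, with a stated time of 72 h; a lower number here means that less compound is needed, a higher number that more compound is needed for the effect. Compound 1 `Cc1ccccc1C(=O)Nc1nc(-c2ccccn2)cs1` gives 6300 nM, compound 2 `O=C(Nc1nc(-c2ccccn2)cs1)c1ccccc1Br` gives 3500 nM, and compound 3 `O=C(Nc1nc(-c2ccccn2)cs1)c1ccccc1Cl` gives 2000 nM, the lowest of the three numbers; its lead is described by a 1.8-fold lower number from compound 2 to compound 3 (0.24 log units; within the scatter) and a 3.2-fold lower number from compound 1 to compound 3 (0.50 log units; beyond the scatter). Compound 4 `O=C(Nc1nc(-c2ccccn2)cs1)c1ccccn1` differs from compound 3 by pyridin-2-yl in place of 2-chlorophenyl on a carbonyl carbon. Among the compounds with values here, the measured steps, a 1.8-fold lower number from compound 1 to compound 2 (0.26 log units; within the scatter) and a 3.2-fold lower number from compound 1 to compound 3 (0.50 log units; beyond the scatter), each exchanged only one group on an aromatic carbon and stayed modest, so none bears directly on replacing the whole ring. The expected step in this assay is therefore a 2.5-fold higher number from compound 3 to compound 4 (0.40 log units; beyond the scatter), a small rise carrying wide uncertainty. Compound 4 is estimated at 5000 nM, within a range from 2000 nM to 13000 nM.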

Compound 4, half-maximal effective concentration: 5400 nM
Compound 4: middle estimate off by 1.1-fold (0.03 log units), on the low side; the measured number falls inside the stated range.
By their numbers in this assay, from the lowest: compounds 3, 2, 4 and 1 (each within the scatter of the next, the first and the last beyond it).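

In this assay, replacing the whole ring on the carbonyl carbon, rather than one group on that ring, still gives a modest step: a 2.7-fold higher number from compound 3 to compound 4 (0.43 log units; beyond the scatter). The other two comparisons, a 1.5-fold higher number from compound 2 to compound 4 (0.19 log units; within the scatter) and a 1.2-fold lower number from compound 1 to compound 4 (0.07 log units; within the scatter), show that pyridin-2-yl stays within the scatter of 2-bromophenyl and 2-methylphenyl, so only 2-chlorophenyl stands apart from it. Nothing measured here explains these numbers. Still open, on these data alone, is how this assay would respond to an amine or a carboxylic acid on the pyridin-2-yl ring.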